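Compound 3 to compound 4: one methyl removed

The compounds below may be only part of what the source reports. "The series", "measured", "known", "first", "only" and "open" are said of these compounds alone.

Compound 1 `COc1cccc(F)c1CNC(=O)c1[nH]c2ccc(Cl)cc2c1S(=O)(=O)c1cc(C)cc(C)c1`: > 49900 nM (a limit)
Compound 2 `Cc1cc(C)cc(S(=O)(=O)c2c(C(=O)NC(C)c3ccco3)[nH]c3ccc(Cl)cc23)c1`: > 54700 nM (a limit)
Compound 3 `Cc1cc(C)cc(S(=O)(=O)c2c(C(=O)NCC(=O)NC(C)c3ccccc3F)[nH]c3ccc(Cl)cc23)c1`: 23000 nM

In an ADME assay on MT4 cells (Homo sapiens) for cytotoxicity, read by MTT assay (a higher number here means that more compound is tolerated, a lower number that less compound is tolerated), compound 3 is the only one of the three with a number, 23000 nM. Compound 4 `Cc1cc(C)cc(S(=O)(=O)c2c(C(=O)NCC(=O)NCc3ccccc3F)[nH]c3ccc(Cl)cc23)c1` differs from it by hydrogen in place of methyl on a saturated chain carbon bound to an amide-type nitrogen and an aromatic carbon. Among the measured compounds shown here, no measured step isolates this change. The nearest is an at least 2.1-fold lower number from compound 1 to compound 3 (0.33 log units; beyond the scatter), a much larger exchange that does not single out the methyl. The other is a step that the two limits leave unreadable from compound 1 to compound 2, which gives no size. The expected change is therefore small, with a 1.2-fold higher number from compound 3 to compound 4 (0.09 log units; within the scatter) estimated. Compound 4 is expected at 28000 nM, with an estimated range of 13000 nM to 60000 nM.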

Compound 4, half-maximal cytotoxic concentration: > 47300 nM
Compound 4 gave a limit, no number; the forecaster's own chance of this, stated with the estimate: 30%; middle value at least 1.6-fold (0.22 log units) away from the limit.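

In this assay, taking the methyl off the saturated chain carbon bound to an amide-type nitrogen and an aromatic carbon gives an at least 2.0-fold higher number from compound 3 to compound 4 (0.31 log units; beyond the scatter), so this one methyl alone separates compound 3 from compound 4. The earlier steps shown here exchanged far larger parts and could not show this. Compound 4 stands as a limit and not a number: the limit of > 47300 nM in this assay, at which 1 of the 4 values shown sits. The steps from compound 1 and from compound 2 to compound 4 join two limits and cannot be read. As far as these compounds go, whether an ethyl or a hydroxymethyl on this carbon would act like the methyl remains open.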